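Removing the Methyl at the Far End of the Core

A few compounds are considered here, and "the series" means these few. Any claim that something is new, unique, unknown or untested is made for them only; others in the source may bear on it.

Compound 2, `Cc1ccc(-c2nc3sc(Cc4ccc(Cl)cc4)nn3c2Br)cc1`, shares its core with compound 1, `Clc1ccc(Cc2nn3c(Br)c(-c4ccc(Br)cc4)nc3s2)cc1`. In an ADME assay on CCRF-CEM cells (Homo sapiens) for cytotoxicity, with a stated time of 72 h (a lower number here means a stronger inhibitor, a higher number a weaker inhibitor), compound 1 gives 238000 nM. In this assay compound 2 reaches only the limit of the measurement, > 250000 nM, so no number is known for it. The step of an at least 1.0-fold higher number from compound 1 to compound 2 (0.02 log units; that floor lies within the scatter) is therefore only a floor, and compound 2 sits at the limit of > 250000 nM in this assay, at which 1 of the 2 values shown sits. Compound 3, `Clc1ccc(Cc2nn3c(Br)c(-c4ccccc4)nc3s2)cc1`, differs from compound 2 by hydrogen in place of methyl on an aromatic carbon, that is 4-methylphenyl to phenyl, with the hydrogen entering on an aromatic carbon of a six-membered aromatic ring of carbon only, para to a large group. For the measured compounds named here, no measured pair shows this exact exchange; the one measured step, an at least 1.0-fold higher number from compound 1 to compound 2 (0.02 log units; that floor lies within the scatter), swapped bromo for methyl at that place and gave nothing beyond the scatter. A step of no size beyond the scatter is therefore expected in this assay for compound 3, and the result may again come back as a limit. Compound 3 is estimated at 250000 nM, with a range from 120000 nM to 500000 nM, which means an expected step of a number no higher from compound 2 to compound 3 (the limit leaves the size open).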

Compound 3, half-maximal inhibitory concentration: > 250000 nM
Compound 3 was reported as a limit; the forecaster's own chance of this, stated with the estimate: 60%; the middle value lies on the limit itself.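

Bromo, methyl and plain hydrogen have now all been seen at this place on the aromatic ring, and in this assay hydrogen in place of bromo gives an at least 1.0-fold higher number from compound 1 to compound 3 (0.02 log units; that floor lies within the scatter). The step between compound 2 and compound 3 cannot be read, as both values are limits. New here is that with neither bromo nor methyl at this place, compound 3 also stays at the limit of the measurement, so none of the three groups shown gives a number beyond the scatter of compound 1: the limit of > 250000 nM in this assay, at which 2 of the 3 values shown sit.

On these data alone, how far compound 2 and compound 3 lie past that limit remains unknown, and so no order among the three compounds can be given. Also open, as far as these compounds go, is whether an amine or a carboxylic acid at this place would give a clearly lower number than compound 1 in this assay.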